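Changing the aryl group on the sulfonyl sulfur

The compounds below may be only part of what the source reports. "The series", "measured", "known", "first", "only" and "open" are said of these compounds alone.

Compound 1 `CNC(=O)/C=C1/COc2cc(OS(=O)(=O)c3cccc(F)c3)ccc21`: 41 nM
Compound 2 `CNC(=O)/C=C1/COc2cc(OS(=O)(=O)c3ccc(C(C)=O)cc3)ccc21`: 29 nM

In an assay (strain Sprague-Dawley) for inhibition of Amine oxidase [flavin-containing] A (Rattus norvegicus), read by spectrophotometry, with a stated time of 5 min (a lower number here means a stronger inhibitor, a higher number a weaker inhibitor), compound 2 stands at the lower of the two numbers, with compound 1 the nearest, yet a 1.4-fold lower number from compound 1 to compound 2 (0.15 log units; within the scatter), so the two cannot be told apart. Compound 3 `CNC(=O)/C=C1/COc2cc(OS(=O)(=O)c3ccc(OC)cc3)ccc21` carries a further change on the same ring: methoxy in place of acetyl on an aromatic carbon. Within the data shown here, the only step that bears on this exchange is the one from compound 1 to compound 2, which stayed within the scatter, so no movement beyond the scatter is expected here either. Compound 3 is therefore expected near 35 nM, between 12 nM and 100 nM, a step of a 1.2-fold higher number from compound 2 to compound 3 (0.08 log units; within the scatter).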

Compound 3, half-maximal inhibitory concentration: 11 nM
For compound 3 the middle estimate is 3.2-fold (0.50 log units) above the measured one; measured number outside the range, below it.
By their numbers in this assay, from the lowest: compound 3; then compounds 2 and 1 (each within the scatter of the next).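

In this assay the aryl group on the sulfonyl sulfur now proves able to shift the number beyond the scatter, which the earlier pair did not show. Methoxy in place of acetyl on the aromatic carbon gives a 2.6-fold lower number from compound 2 to compound 3 (0.42 log units; beyond the scatter) and 4-methoxyphenyl in place of 3-fluorophenyl gives a 3.7-fold lower number from compound 1 to compound 3 (0.57 log units; beyond the scatter). Nothing available here explains this modest gain. The compounds shown leave open whether it is specific to methoxy or would also appear with ethoxy, a hydroxyl or an amine at the same place. They also leave open how methoxy would fare elsewhere on the ring.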